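A few compounds are considered here, and "the series" means these few. Any claim that something is new, unique, unknown or untested is made for them only; others in the source may bear on it.

Measured compounds:

Compound 1, `c1cncc(CN(CCCCN(C[C@H]2Cc3ccccc3CN2)[C@H]2CCCc3cccnc32)Cc2cccnc2)c1`, gives 471 nM in a functional assay on cells for antagonist activity at C-X-C chemokine receptor type 4 (Homo sapiens), read by fluorescence and calcium flux, with stated times of 25 min and 90 s; on this read-out lower numbers stand for stronger inhibition and higher numbers for weaker inhibition.
Compound 2, `c1ccc2c(c1)CN[C@@H](CN(CCCCNCc1ccncc1)[C@H]1CCCc3cccnc31)C2`, gives 22.7 nM in this assay.
Compound 3, `c1ccc2c(c1)CN[C@@H](CN(CCCCNCC1CCOCC1)[C@H]1CCCc3cccnc31)C2`, gives 52.9 nM in this assay.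

Compound 2 stands lowest of the three numbers: compound 3 comes nearest, compound 1 lies furthest away with the highest number. The compound that follows is compound 4, `c1ccc2c(c1)CN[C@@H](CN(CCCCNCC1CCSCC1)[C@H]1CCCc3cccnc31)C2`, which has not yet been measured in this assay. It differs from compound 2 in one place: thian-4-yl in place of pyridin-4-yl on a saturated chain carbon bound to an amine nitrogen. For the measured compounds named here, only one measured step bears on this change, the one in which the same aromatic ring gave way to a saturated six-membered ring with one oxygen: a 2.3-fold higher number from compound 2 to compound 3 (0.37 log units; beyond the scatter). Since the change to compound 4 again trades the aromatic ring for a saturated six-membered ring with one hetero atom, a modest rise in the number is expected, of about the size seen for compound 3; she therefore expects a 2.2-fold higher number from compound 2 to compound 4 (0.34 log units; beyond the scatter). Compound 4 is estimated at 50 nM, within a range from 20 nM to 130 nM.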

Compound 4, half-maximal inhibitory concentration: 69.6 nM
The estimate for compound 4 lay 1.4-fold (0.14 log units) below the measured number, within the range that was stated.
By their numbers in this assay, from the lowest: compound 2; then compounds 3 and 4 (each within the scatter of the next); then compound 1.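

In this assay, a second saturated ring on a saturated chain carbon bound to an amine nitrogen also gives a higher number than the pyridin-4-yl of compound 2 (a 3.1-fold higher number from compound 2 to compound 4 (0.49 log units; beyond the scatter)), so this rise now holds for both saturated rings shown, not just for oxan-4-yl. Exchanging the ring oxygen for sulfur makes no difference that can be read (a 1.3-fold higher number from compound 3 to compound 4 (0.12 log units; within the scatter)), so the two saturated rings cannot be told apart at this place. Nothing given here explains these steps.

From the compounds shown here alone, it remains open whether the rise goes with the loss of the aromatic ring or with the loss of the ring nitrogen. A phenyl ring or a cyclohexyl ring at this place would bear on that question, and a piperidin-4-yl ring would show how a saturated ring with a ring nitrogen compares.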